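This account rests on a few compounds, and the source may have more. Where it says the series, first, only, none or still open, it means among the compounds named here.

Measured compounds:
Compound 1, `Fc1ccc(OCCCN2CCN(c3ncc(F)cn3)CC2)cc1`, 89 nM in an assay (Cavia porcellus) for displacement of a labelled ligand from Sigma non-opioid intracellular receptor 1 (Homo sapiens); on this read-out higher numbers stand for weaker inhibition and lower numbers for stronger inhibition.
Compound 2, `Fc1ccc(SCCCN2CCN(c3ncc(F)cn3)CC2)cc1`, 51 nM in this assay.

Among the measured compounds shown here, compound 2 gives the lowest of the two numbers recorded in this assay, and its nearest neighbour is compound 1; the one step that connects them, a 1.7-fold lower number from compound 1 to compound 2 (0.24 log units; within the scatter), lies within the scatter, so the two compounds cannot be ranked. Compound 3, `NC(CCCN1CCN(c2ncc(F)cn2)CC1)C1CCCCC1`, has not yet been measured in this assay. Its change from compound 2 is amino(cyclohexyl)methyl in place of (4-fluorophenyl)sulfanyl on a saturated chain carbon, three bonds along the chain from an amine nitrogen in a ring. For the measured compounds named here, the only measured step, that from compound 1 to compound 2, exchanges one group on this same chain carbon for another and was small; it gives no direct guidance on a change of this kind, where an aromatic ring is traded for a saturated ring and a hydrogen-bond donor appears. Compound 3 is therefore expected to show a modest rise in number, a 2.9-fold higher number from compound 2 to compound 3 (0.47 log units; beyond the scatter), in this assay, with a wide range. Compound 3 is estimated at 150 nM, between 40 nM and 600 nM.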

Compound 3, half-maximal inhibitory concentration: 52 nM
Compound 3: middle estimate off by 2.9-fold (0.46 log units), on the high side; the range from low to high includes it.
By their numbers in this assay, from the lowest: compounds 2, 3 and 1 (each within the scatter of the next).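

In this assay, amino(cyclohexyl)methyl in place of (4-fluorophenyl)sulfanyl gives a 1.0-fold higher number from compound 2 to compound 3 (0.01 log units; within the scatter), and amino(cyclohexyl)methyl in place of 4-fluorophenoxy gives a 1.7-fold lower number from compound 1 to compound 3 (0.23 log units; within the scatter). This chain carbon had so far been shown carrying only groups with a six-membered aromatic ring of carbon, and a group with a six-membered non-aromatic ring of carbon and a hydrogen-bond donor now cannot be separated from them on this read-out. No supporting measurement is available to explain this result.

The amino group and the cyclohexyl ring enter together, and the compounds shown do not separate their contributions. As far as these compounds go, it also remains open how a cyclohexylmethyl group without the amine, or a carboxylic acid in its place, would read in this assay.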